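Aryl and pyridyl groups on the ring nitrogen: tolerance notes

The source may hold more compounds than are shown below. What is called first, only, known or untested is meant among the compounds shown, and "the series" means these compounds.

Compound 1 `COc1ccc([C@H]2CC(=O)N(C(C)=O)C2)cc1OC1CCCC1` is the reference for this comparison. In a functional assay on HEK293 cells (Homo sapiens) for cytotoxicity (a lower number here means that less compound is tolerated, a higher number that more compound is tolerated), compound 1 gives > 10000 nM, which is a limit of the assay rather than a measured number. Compound 2 `COc1ccc([C@H]2CC(=O)N(c3cccc(O)c3)C2)cc1OC1CCCC1` gives > 10000 nM in this assay, again only a limit. Compound 3 `COc1ccc([C@H]2CC(=O)N(c3ccc(C(F)(F)F)cc3)C2)cc1OC1CCCC1` gives > 10000 nM in this assay, likewise a limit. The steps a step that the two limits leave unreadable from compound 1 to compound 2, a step that the two limits leave unreadable from compound 1 to compound 3 and a step that the two limits leave unreadable from compound 2 to compound 3 cannot be sized, since the limit of > 10000 nM in this assay, at which 3 of the 3 values shown sit, holds for every value seen. Compound 4 `COc1ccc([C@H]2CC(=O)N(c3ccccn3)C2)cc1OC1CCCC1` differs from compound 1 by pyridin-2-yl in place of acetyl on an amide-type nitrogen in a ring. The two measured replacements of acetyl by an aromatic group on the same nitrogen left the limit untouched, so no shift beyond the scatter is expected in this assay. Compound 4 is expected at 15000 nM, between 7000 nM and 40000 nM. The step that the limit leaves unreadable from compound 1 to compound 4 is expected to fall within the scatter.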

Compound 4, half-maximal cytotoxic concentration: > 10000 nM
Compound 4: only a limit was reported; the forecaster's own chance of this, stated with the estimate: 80%; the middle value lies beyond the limit too.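

In this assay compound 4 gives > 10000 nM as a limit of the assay. Within the data shown here, no step to compound 4 from compound 1, compound 2 or compound 3 can be read: the limit of > 10000 nM in this assay, at which 4 of the 4 values shown sit.

The compounds shown leave open at what concentration any of them becomes cytotoxic, and whether the groups on the ring nitrogen differ at all in this assay.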